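This account rests on a few compounds, and the source may have more. Where it says the series, first, only, none or still open, it means among the compounds named here.

Measured so far:
- compound 1, `O=C(Nc1ccc(OC(F)(F)F)cc1)Nc1cccnc1Oc1cccc2c1CCNC2`, with 3000 nM in an assay on HEK293 cells for displacement of a labelled ligand from P2Y purinoceptor 1 (Homo sapiens), read by scintillation counting, with a stated time of 1 h; a higher number here means a weaker inhibitor, a lower number a stronger inhibitor
- compound 2, `CC(C)CN1Cc2cccc(Oc3ncccc3NC(=O)Nc3ccc(OC(F)(F)F)cc3)c2C1`, with 68 nM in this assay
- compound 3, `CN1Cc2cccc(Oc3ncccc3NC(=O)Nc3ccc(OC(F)(F)F)cc3)c2C1C(C)(C)C`, with 57 nM in this assay

Among these three, compound 3 shows the lowest number. Its nearest neighbour is compound 2, whose value lies within the usual scatter, so the two cannot be told apart. Compound 1 stands well beyond the scatter from compound 3, with a far higher number.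

The next compound, compound 4, `CN1Cc2cccc(Oc3ncccc3NC(=O)Nc3ccc(OC(F)(F)F)cc3)c2C1`, differs from compound 3 in a single way: hydrogen in place of tert-butyl on a saturated ring carbon. The tert-butyl group is lost and nothing but a hydrogen takes its place, while the methyl on the ring nitrogen stays.

Among the measured compounds shown here, no pair of compounds differing only in this group has been measured, so the size of this step is not known from a neighbouring case. Compound 1, which carries hydrogen at that carbon and also on the ring nitrogen, gives a much higher number than compound 3, but it differs in two places and offers no direct guide. The step from compound 3 to compound 4 is expected to raise the number by a 6.1-fold higher number from compound 3 to compound 4 (0.79 log units; beyond the scatter), with real uncertainty about its size. For compound 4 the expected value in this assay is 350 nM, within a range from 80 nM to 1500 nM.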

Compound 4, inhibition constant: 3700 nM
For compound 4 the middle estimate is 11-fold (1.02 log units) below the measured one; measured number above the stated range.
By their numbers in this assay, from the lowest: compounds 3 and 2 (each within the scatter of the next); then compounds 1 and 4 (each within the scatter of the next).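

Replacing tert-butyl with hydrogen on the saturated ring carbon gives a 65-fold higher number from compound 3 to compound 4 (1.81 log units; beyond the scatter) in this assay while the methyl on the ring nitrogen stays, so this position has a large effect on the number and the methyl alone does not bring it down to the level of compound 3. Hydrogen in place of isopropyl on a saturated chain carbon bound to an amine nitrogen in a ring gives a 54-fold higher number from compound 2 to compound 4 (1.74 log units; beyond the scatter) and is also a large step, so compound 4, which has neither of these groups, stands far from both compound 2 and compound 3. The exchange of the group on the oxygen on an aromatic ring, a six-membered non-aromatic ring for a five-membered one, gives a 1.2-fold higher number from compound 1 to compound 4 (0.09 log units; within the scatter) and lies within the scatter, so compound 1 and compound 4 cannot be told apart.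

Nothing in the data gives a measured reason for these large steps. Going by these compounds, it remains open whether a methyl or ethyl group on the saturated ring carbon would be enough to bring the number down, or how a hydroxyl group or an amine at that carbon would compare with tert-butyl.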